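This account rests on a few compounds, and the source may have more. Where it says the series, first, only, none or still open, it means among the compounds named here.

Compound 1 `CC[C@@H](Nc1nc(NCc2ccccn2)c2ncn(C(C)C)c2n1)C(C)O` in a functional assay on KM12 cells (Homo sapiens) for inhibition, read by sulforhodamine B assay, with a stated time of 96 h (a lower number here means a stronger inhibitor of growth, a higher number a weaker inhibitor of growth), gives 37000 nM. Compound 2 `CCC(O)[C@@H](CC)Nc1nc(NCc2ccccn2)c2ncn(C(C)C)c2n1` gives 45000 nM. Compound 3 `CC[C@H](Nc1nc(NCc2ccccn2)c2ncn(C(C)C)c2n1)C(C)(C)O` gives 38000 nM.

Compound 3 stands second highest of these three numbers, but the spread is small: its nearest neighbour is compound 1, with a 1.0-fold higher number from compound 1 to compound 3 (0.01 log units; within the scatter), and its furthest is compound 2, with a 1.2-fold lower number from compound 2 to compound 3 (0.07 log units; within the scatter). Both gaps lie within the scatter, so the three measured compounds are in effect level in this assay.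

Compound 4 `CC[C@H](Nc1nc(NCc2ccccn2)c2ncn(C(C)C)c2n1)C(O)C(C)(C)C` has not yet been measured. It differs from compound 3 by 1-hydroxy-2,2-dimethylpropyl in place of 1-hydroxy-1-methylethyl on a saturated chain carbon bound to a nitrogen on an aromatic ring and a saturated chain carbon. For the measured compounds named here, three measured steps bear on this change, all of them alterations of the saturated side chain around its hydroxyl. Adding a methyl along the chain gave a 1.2-fold higher number from compound 1 to compound 2 (0.09 log units; within the scatter); adding a methyl to the carbon carrying the hydroxyl gave a 1.0-fold higher number from compound 1 to compound 3 (0.01 log units; within the scatter); and the exchange of the two branched chains gave a 1.2-fold lower number from compound 2 to compound 3 (0.07 log units; within the scatter). None of these moved the number beyond the scatter. Growing the chain further to the 1-hydroxy-2,2-dimethylpropyl group is therefore expected to leave the number essentially where compound 3 sits, with no step beyond the scatter in either direction.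

Compound 4 is accordingly estimated at 40000 nM, with a range from 18000 nM to 90000 nM. This expected step reads a 1.1-fold higher number from compound 3 to compound 4 (0.02 log units; within the scatter).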

Compound 4, concentration for 50% growth inhibition: 36000 nM
Beside the measured number, compound 4's estimate is 1.1-fold (0.05 log units) above it; the measured number falls inside the stated range.
By their numbers in this assay, from the lowest: compounds 4, 1, 3 and 2 (each within the scatter of the next).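

Compound 4 carries 1-hydroxy-2,2-dimethylpropyl, with 6 heavy atoms, in place of the 4 heavy atoms of 1-hydroxy-1-methylethyl on a saturated chain carbon bound to a nitrogen on an aromatic ring and a saturated chain carbon, and this gives a 1.1-fold lower number from compound 3 to compound 4 (0.02 log units; within the scatter) in this assay. For the compounds shown here, measured against the other two side chains, 1-ethyl-2-hydroxy-3,3-dimethylbutyl gives a 1.3-fold lower number from compound 2 to compound 4 (0.10 log units; within the scatter) when it replaces 1-ethyl-2-hydroxybutyl and a 1.0-fold lower number from compound 1 to compound 4 (0.01 log units; within the scatter) when it replaces 1-(1-hydroxyethyl)propyl, so the level seen among the earlier compounds now also covers a side chain with more carbon than any of theirs. Nothing available here accounts for how little the number responds to these changes.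

Going by these compounds, all four compounds keep a hydroxyl on this side chain and share the same core, so it remains open whether an amine or a carboxylic acid in that role would leave the number level. On these data alone, it is equally open whether a phenyl ring or a much longer chain at this place would move the number beyond the scatter in either direction.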